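Replacing Phenoxy with 4-Fluorophenyl on a Piperidine Urea

The source may report more compounds than this note shows. Statements on the series, on what has been measured and on what is new or still open speak of the compounds shown alone.

The series is followed in an ADME assay on cells (Peritoneal macrophage cell, Mus musculus) for cytotoxicity, read by fluorescence and resazurin assay, with a stated time of 3 days; on this read-out lower numbers stand for higher toxicity in this test and higher numbers for lower toxicity in this test. Compound 1 `O=C(Nc1cc(-c2ccccn2)n[nH]1)N1CCC(Oc2ccccc2)CC1` returns only a limit there, > 40000 nM, so its true value is not known beyond that. Two further compounds also return limits. Compound 2 `O=C(Nc1[nH]nc(-c2ccccn2)c1C1CC1)c1c(Cl)cccc1Cl` gives a limit of > 64000 nM. Compound 3 `O=C(NCc1ccccc1)Nc1[nH]nc(-c2ccccn2)c1Cl` likewise gives a limit of > 64000 nM. Thus compound 1 stands among compounds for which this assay reports no number, and the evidence consists of the limit of > 40000 nM in this assay, at which 1 of the 3 values shown sits, and (the limit of > 64000 nM in this assay, at which 2 of the 3 values shown sit).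

Compound 4 `O=C(Nc1cc(-c2ccccn2)n[nH]1)N1CCC(c2ccc(F)cc2)CC1` differs from compound 1 by 4-fluorophenyl in place of phenoxy on a saturated ring carbon. Among the compounds with values here, no measured step between two compounds is available to set a scale for this change.

Given that compound 1 sits at a limit in this assay, the author expects compound 4 to show no change beyond the scatter and to remain at or near a limit as well. The estimate for compound 4 is 50000 nM, within 20000 nM to 120000 nM. The expected step is a step that the limit leaves unreadable from compound 1 to compound 4.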

Compound 4, half-maximal cytotoxic concentration: > 64000 nM
Compound 4: a limit, no number; the forecaster's own chance of this, stated with the estimate: 70%; middle value at least 1.2-fold (0.10 log units) from the limit.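

In this assay compound 4 gives > 64000 nM, which is a limit. Compound 1 gives > 40000 nM, also a limit, so the step between compound 1 and compound 4 cannot be read. The compounds shown leave open whether 4-fluorophenyl in place of phenoxy changes the read-out in this assay at all.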